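Glycinamide series: benzyl(methyl)amino in place of diisopropylamino

This account rests on a few compounds, and the source may have more. Where it says the series, first, only, none or still open, it means among the compounds named here.

Compound 3 `CC(C)N(C(=O)CNC(=O)c1ccc(S(C)(=O)=O)c([N+](=O)[O-])c1)C(C)C` gives in an assay on isolated protein for inhibition of thyroid hormone receptor beta (Homo sapiens), read by fluorescence polarization (a higher number here means a weaker inhibitor, a lower number a stronger inhibitor), only a limit, > 60000 nM. Compound 2 `CS(=O)(=O)c1ccc(C(=O)NCC(=O)N2CCCCC2)cc1[N+](=O)[O-]` likewise reaches only a limit in this assay, > 60000 nM. The step that the two limits leave unreadable from compound 2 to compound 3 is therefore unreadable, both values sitting at the limit of > 60000 nM in this assay, at which 2 of the 3 values shown sit. Compound 1 `CN(Cc1ccccc1F)C(=O)CNC(=O)c1ccc(S(C)(=O)=O)c([N+](=O)[O-])c1` does give a number in this assay, 24000 nM. Compound 4 `CN(Cc1ccccc1)C(=O)CNC(=O)c1ccc(S(C)(=O)=O)c([N+](=O)[O-])c1` differs from compound 3 by benzyl(methyl)amino in place of diisopropylamino on a carbonyl carbon. Within the data shown here, no measured step covers this exchange; compound 4 carries the same benzyl(methyl)amino group as compound 1 and differs from it only by the fluorine, so compound 1 is the nearest anchor. Compound 4 is expected to give 30000 nM, within 12000 nM to 60000 nM. The expected step of an at least 2.0-fold lower number from compound 3 to compound 4 (0.30 log units; that floor lies within the scatter) runs from a limit to a readable value, toward stronger inhibition.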

Compound 4, half-maximal inhibitory concentration: 39000 nM
Beside the measured number, compound 4's estimate is 1.3-fold (0.11 log units) below it; measured number inside the range.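

In this assay, benzyl(methyl)amino on the carbonyl carbon gives a readable value where the other two amines do not, with an at least 1.5-fold lower number from compound 3 to compound 4 (0.18 log units; that floor lies within the scatter) and an at least 1.5-fold lower number from compound 2 to compound 4 (0.18 log units; that floor lies within the scatter). Hydrogen in place of fluoro gives a 1.6-fold higher number from compound 1 to compound 4 (0.21 log units; within the scatter), so a readable value does not depend on the fluoro. Compound 2 and compound 3 each remain only a limit: the limit of > 60000 nM in this assay, at which 2 of the 4 values shown sit.

Still open, on these data alone, is how a carboxylic acid or a dimethylamino group on the aromatic ring of the benzyl group would read. Also open, as far as these compounds go, is whether phenethyl(methyl)amino, with its longer chain, would read differently from benzyl(methyl)amino.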